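A few compounds are considered here, and "the series" means these few. Any claim that something is new, unique, unknown or untested is made for them only; others in the source may bear on it.

Among the measured compounds shown here, compound 1 `Nc1ccccc1NC(=O)c1ccc(CSC(=S)N2CCN(Cc3ccccn3)CC2)cc1` is the weaker of the two measured members: in a functional assay on MGC-803 cells (Homo sapiens) for antiproliferative activity, read by CCK-8 assay, with a stated time of 72 h, tested at 2 uM (on this read-out lower numbers stand for a weaker effect and higher numbers for a stronger effect at the one concentration tested), compound 1 gives 23.4%, the lowest of the two numbers recorded. Compound 2 `Nc1ccccc1NC(=O)c1ccc(CSC(=S)N2CCN(Cc3cccnc3)CC2)cc1` differs from it only by pyridin-3-yl in place of pyridin-2-yl on a saturated chain carbon bound to an amine nitrogen in a ring, and in this assay compound 2 gives 37.7%; the step of a number 14.3 percentage points higher from compound 1 to compound 2 (beyond the scatter) shows that a change of the aromatic ring at this position can move the read-out beyond the scatter.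

Compound 3 `Nc1ccccc1NC(=O)c1ccc(CSC(=S)N2CCN(Cc3ccccc3)CC2)cc1` is not yet measured. It differs from compound 1 by phenyl in place of pyridin-2-yl on a saturated chain carbon bound to an amine nitrogen in a ring. For the measured compounds named here, no measured step covers the removal of the hetero atom from that ring; the only step bearing on this position is a number 14.3 percentage points higher from compound 1 to compound 2 (beyond the scatter), which was modest. Lacking a closer precedent, the expected step of a number 5.6 percentage points higher from compound 1 to compound 3 (within the scatter) is small and uncertain in direction. Compound 3 is estimated at 29%, within a range from 14% to 44%.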

Compound 3, a percentage reported as inhibition, at one concentration (the size of the read-out at that concentration, not a potency): 18.1%
Estimate against measurement, compound 3: 10.9 percentage points above, and the stated range covers the measured number.
By their numbers in this assay, from the lowest: compounds 3 and 1 (each within the scatter of the next); then compound 2.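

Read in this assay, the step of a number 5.3 percentage points lower from compound 1 to compound 3 (within the scatter) puts phenyl and pyridin-2-yl on a par at this saturated chain carbon, while the step of a number 19.6 percentage points lower from compound 2 to compound 3 (beyond the scatter) separates phenyl from pyridin-3-yl. Among these three compounds, a ring nitrogen alone therefore does not set the read-out: compound 1 carries one and stays within the scatter of compound 3, and only the pyridin-3-yl of compound 2 stands clear of both other groups. No evidence on hand explains why the pyridin-3-yl group stands apart.

Still open, from the compounds shown here alone, is whether a pyridin-4-yl group, or a longer chain between the piperazine-side amine nitrogen and the aromatic ring, would stay with compound 2 or fall with compound 1 and compound 3. A read-out at one concentration also leaves the potency order of the three open.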